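A few compounds are considered here, and "the series" means these few. Any claim that something is new, unique, unknown or untested is made for them only; others in the source may bear on it.

Measured compounds:
- compound 1, `Nc1n[nH]c2cc(-c3ccc(=O)n(Cc4cccc(Cl)c4)c3)ccc12`: 6 nM
- compound 2, `O=c1ccc(-c2ccc3cn[nH]c3c2)cn1Cc1cccc(C(F)(F)F)c1`: 32 nM
- compound 3, `Cn1cc2ccc(-c3ccc(=O)n(Cc4ccccc4)c3)cc2n1`: > 2000 nM

The read-out throughout is an assay for inhibition of MAP kinase-interacting serine/threonine-protein kinase 2 (Homo sapiens), read by luminescence and ADP-Glo, with a stated time of 2 h; on this read-out higher numbers stand for weaker inhibition and lower numbers for stronger inhibition. Of the two compounds with a number, compound 2 stands at the higher one; compound 1 gives the lower number, and the gap between them is beyond the scatter. For compound 3 only a limit is recorded, (the limit of > 2000 nM in this assay, at which 1 of the 3 values shown sits), so it gives no number to compare with.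

Compound 4, `O=c1ccc(-c2ccc3cn[nH]c3c2)cn1Cc1cccc(F)c1`, has not yet been measured. It differs from compound 2 in one place: fluoro in place of trifluoromethyl on an aromatic carbon. The change is fluoro in place of trifluoromethyl on an aromatic carbon; nothing else in the structure moves.

Among the compounds with values here, no measured pair separates these two groups, so the expectation rests on the change itself and on the value of compound 2, 32 nM. The step from compound 2 to compound 4 is expected to be small, a 1.1-fold lower number from compound 2 to compound 4 (0.03 log units; within the scatter), and not beyond the scatter in either direction. Compound 4 is therefore estimated at 30 nM, within a range of 10 nM to 100 nM in this assay.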

Compound 4, half-maximal inhibitory concentration: 38 nM
For compound 4 the middle estimate is 1.3-fold (0.10 log units) below the measured one, within the range that was stated.
By their numbers in this assay, from the lowest: compound 1; then compounds 2 and 4 (each within the scatter of the next). At a limit, above all of these: compound 3.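

In this assay, within the data shown here, fluoro in place of trifluoromethyl on an aromatic carbon, meta to a large group, gives a 1.2-fold higher number from compound 2 to compound 4 (0.07 log units; within the scatter), which is the only step so far between compounds that differ in one place. It shows that this read-out does not separate the two groups at this position, even though a group of 4 heavy atoms gives way to one of 1 heavy atom, so the size of the group alone, across this span, does not move the number beyond the scatter. Nothing measured here bears on why the two groups read alike.

Going by these compounds, both groups tested at this position carry fluorine, so it remains open whether a group without it, such as an amine, a carboxylic acid or a methoxy group, would also stay within the scatter of compound 2 on the same aromatic carbon. On these data alone, compound 1 and compound 3 each differ from compound 2 in more than one place, so no single change can be read from them, and it also remains open whether this position would respond in the same way on the core of compound 1.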